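The source may hold more compounds than are shown below. What is called first, only, known or untested is meant among the compounds shown, and "the series" means these compounds.

Measured compounds:
- compound 1 `CCCCCCc1c(F)c(N)c2c(=O)cc(-c3ccc(N)c(F)c3)oc2c1F` — > 10000 nM
- compound 2 `Nc1ccc(-c2cc(=O)c3c(N)c(F)c(O)c(F)c3o2)cc1F` — > 10000 nM

In a functional assay on MCF7 cells (Homo sapiens) for cytotoxicity, read by neutral red uptake, with a stated time of 3 days (on this read-out lower numbers stand for stronger inhibition and higher numbers for weaker inhibition), compound 1 reaches only a limit of the assay, > 10000 nM. In this assay compound 2 likewise reaches only a limit, > 10000 nM. For the measured compounds named here, the one measured step, a step that the two limits leave unreadable from compound 1 to compound 2, is therefore not readable in size or direction: both ends sit at the limit of > 10000 nM in this assay, at which 2 of the 2 values shown sit. Where compound 2 stands can only be given as that limit; no number places it within the measured range.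

Compound 3 `COc1c(F)c(N)c2c(=O)cc(-c3ccc(N)c(F)c3)oc2c1F` differs from compound 2 by methyl in place of hydrogen on an oxygen on an aromatic ring. Going by the values given here, no measured step bears on this change in a readable way, since the only step, a step that the two limits leave unreadable from compound 1 to compound 2, is unreadable, and no evidence beyond the limit of > 10000 nM in this assay, at which 2 of the 2 values shown sit, is available. With both neighbours of compound 3 at the limit, no step beyond the scatter can be expected in either direction. Compound 3 is expected at 20000 nM (range 5000 nM to 80000 nM). The expected step is a step that the limit leaves unreadable from compound 2 to compound 3.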

Compound 3, half-maximal inhibitory concentration: 100 nM
The estimate for compound 3 lay 200-fold (2.30 log units) above the measured number, outside the stated range (below it).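

In this assay, replacing hydroxy with methoxy gives an at least 100-fold lower number from compound 2 to compound 3 (2.00 log units; beyond the scatter), so this position on the shared core can carry a readable response, which the earlier pair could not show: the limit of > 10000 nM in this assay, at which 2 of the 3 values shown sit.

Methoxy in place of hexyl on the same aromatic carbon gives an at least 100-fold lower number from compound 1 to compound 3 (2.00 log units; beyond the scatter). Hexyl and hydroxy both leave the compound at the limit while methoxy does not, so across these three compounds the response does not follow chain length in a simple way, and since both steps start from a limit, their full size remains unknown.

The compounds shown leave open whether the effect is specific to methoxy or extends to other groups on this oxygen or carbon, such as ethoxy, a longer alkoxy chain or an amine. They also leave open whether the methyl on the oxygen is enough by itself on a different core, and whether the fluorines and amino groups of the shared core are needed for the response seen with compound 3.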